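A few compounds are considered here, and "the series" means these few. Any claim that something is new, unique, unknown or untested is made for them only; others in the source may bear on it.

For the measured compounds named here, compound 2 `CN(C(=O)NC(=O)c1c(F)cccc1F)c1nc(C(F)(F)F)c(C(=O)N/N=C/c2cccc(C(F)(F)F)c2)s1` is one of two compounds measured in a functional assay on BCG823 cells (Homo sapiens) for inhibition, read by MTT assay, with a stated time of 72 h; on this read-out higher numbers stand for weaker inhibition and lower numbers for stronger inhibition; in this assay compound 2 gives 25.9 ug/mL. Compound 1 `CN(C(=O)NC(=O)c1ccc(Cl)cc1Cl)c1nc(C(F)(F)F)c(C(=O)N/N=C/c2cccc(C(F)(F)F)c2)s1` gives 6.11 ug/mL. Going by the values given here, the one step measured, a 4.2-fold higher number from compound 1 to compound 2 (0.63 log units; beyond the scatter), swapped the group on the carbonyl carbon and leaves compound 2 standing as the higher of the two numbers. Compound 3 `Cc1nc(N(C)C(=O)NC(=O)c2c(F)cccc2F)sc1C(=O)N/N=C/c1cccc(C(F)(F)F)c1` has not yet been measured; it differs from compound 2 by methyl in place of trifluoromethyl on an aromatic carbon. Among the compounds with values here, no measured step touches this part of the shared core: the only step recorded, from compound 1 to compound 2, changed a different group, and no two measured compounds differ in the group on the five-membered ring. There is therefore nothing in the data to support a step in this assay in either direction beyond the scatter, and the plain expectation is that compound 3 lands near compound 2, with a wide range to reflect the lack of any guiding step. Compound 3 is expected to give 25 ug/mL, with a range from 9 ug/mL to 70 ug/mL, which corresponds to an expected step of a 1.0-fold lower number from compound 2 to compound 3 (0.02 log units; within the scatter).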

Compound 3, half-maximal inhibitory concentration: 32.7 ug/mL
The estimate for compound 3 lay 1.3-fold (0.12 log units) below the measured number; measured number inside the range.
By their numbers in this assay, from the lowest: compound 1; then compounds 2 and 3 (each within the scatter of the next).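

In this assay, methyl in place of trifluoromethyl on an aromatic carbon, next to the ring nitrogen, gives a 1.3-fold higher number from compound 2 to compound 3 (0.10 log units; within the scatter). For the compounds shown here, this is the first measured look at this position, and it shows that a group of 4 heavy atoms and a group of 1 heavy atom cannot be told apart here when the 2,6-difluorophenyl group sits on the carbonyl carbon, whereas the only step beyond the scatter so far, a 4.2-fold higher number from compound 1 to compound 2 (0.63 log units; beyond the scatter), lies in a different place on the shared core. No measurement is available that could explain why this swap produces no clear difference.

The compounds shown leave open whether methyl and trifluoromethyl would also match when the 2,4-dichlorophenyl group of compound 1 sits on the carbonyl carbon, as one pair with a single partner group cannot settle that. They also leave open how this position would respond to other groups, such as a plain hydrogen, a longer chain like ethyl, an amine or a carboxylic acid.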